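This account rests on a few compounds, and the source may have more. Where it says the series, first, only, none or still open, it means among the compounds named here.

Measured in a functional assay on L1210 cells (Mus musculus) for antiproliferative activity; on this read-out lower numbers stand for stronger inhibition and higher numbers for weaker inhibition:
- Compound 1 `COc1cc(C(=O)c2sc(-c3ccc(-c4ccccc4)cc3)cc2N)cc(OC)c1OC`: > 10000 nM, a limit
- Compound 2 `COc1cc(C(=O)c2sc(-c3ccc(Br)cc3)cc2N)cc(OC)c1OC`: 100 nM

Among the compounds with values here, compound 2 holds the only actual number so far, since the other result is a limit. Compound 3 `COc1ccc(-c2cc(N)c(C(=O)c3cc(OC)c(OC)c(OC)c3)s2)cc1OC` differs from it by 3,4-dimethoxyphenyl in place of 4-bromophenyl on an aromatic carbon, with 3,4-dimethoxyphenyl in place of 4-bromophenyl on an aromatic carbon. Within the data shown here, the one measured step, an at least 100-fold lower number from compound 1 to compound 2 (2.00 log units; beyond the scatter), altered that same aryl group and was large. It shows that this part of the molecule can matter, so a moderate move toward weaker inhibition in this assay is expected, though the direction is uncertain. The expected change is a 5.0-fold higher number from compound 2 to compound 3 (0.70 log units; beyond the scatter). For compound 3 the estimated value is 500 nM, with an expected range of 60 nM to 5000 nM.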

Compound 3, half-maximal inhibitory concentration: 40 nM
The estimate for compound 3 lay 13-fold (1.10 log units) above the measured number; measured number outside the range, below it.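

In this assay, 3,4-dimethoxyphenyl in place of 4-bromophenyl on the aromatic carbon next to the ring sulfur gives a 2.5-fold lower number from compound 2 to compound 3 (0.40 log units; beyond the scatter). The earlier step on this aryl group ended at a limit, whereas both ends of this one are numbers. It shows that a group with more heavy atoms than 4-bromophenyl, and with two hydrogen-bond acceptors, can go with the lower number here.

Compound 1 remains a limit, and its distance from the others cannot be read: the limit of > 10000 nM in this assay, at which 1 of the 3 values shown sits. As far as these compounds go, it stays open whether a single methoxy group, as in 4-methoxyphenyl, or a 4-aminophenyl group would give a similar number.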